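Carbamate selenocyanates and cytotoxicity on bronchial cells

The compounds below may be only part of what the source reports. "The series", "measured", "known", "first", "only" and "open" are said of these compounds alone.

Measured compounds:
compound 1, `C=CCOC(=O)Nc1ccc([Se]C#N)cc1`: 21400 nM
compound 2, `CCCCOC(=O)Nc1ccc([Se][Se]c2ccc(NC(=O)OCCCC)cc2)cc1`: 24200 nM

In an ADME assay on BEAS-2B cells (Homo sapiens) for cytotoxicity, read by MTT assay, with a stated time of 72 h (a higher number here means a weaker inhibitor of growth, a lower number a stronger inhibitor of growth), compound 1 gives 21400 nM. Compound 2 gives 24200 nM in this assay. For the measured compounds named here, the two numbers sit within the scatter of each other, so neither compound can be said to inhibit growth more strongly than the other; compound 1 simply holds one of the two values known so far, and nothing separates it from compound 2.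

Compound 3, `CC(C)COC(=O)Nc1ccc([Se]C#N)cc1`, has not yet been measured in this assay. It differs from compound 1 in one place only: isopropyl in place of vinyl on a saturated chain carbon bound to an oxygen next to a carbonyl group. The rest of the molecule, the shared core with its selenocyanate, is left as it is.

Going by the values given here, no measured pair of compounds shows what such a change does, so the expectation rests on compound 1 alone. The step from allyl to isobutyl is small, and the author expects that the step of a 1.0-fold higher number from compound 1 to compound 3 (0.01 log units; within the scatter) will stay within the scatter, with no real direction. On that basis the estimate for compound 3 in this assay is 22000 nM, with a range from 8000 nM to 60000 nM.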

Compound 3, concentration for 50% growth inhibition: 26900 nM
Compound 3: the middle estimate sits 1.2-fold (0.09 log units) below what was measured, and the stated range covers the measured number.
By their numbers in this assay, from the lowest: compounds 1, 2 and 3 (each within the scatter of the next).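

In this assay, the change from allyl to isobutyl, isopropyl in place of vinyl on a saturated chain carbon bound to an oxygen next to a carbonyl group, gives a 1.3-fold higher number from compound 1 to compound 3 (0.10 log units; within the scatter). For the compounds shown here, this is the first step at this position that can be read, and it shows that the double bond of the allyl chain can give way to the saturated isobutyl chain with no change that stands out from the scatter, so this one swap does not separate the two compounds. The compounds shown offer no measurement that could explain this result.

The compounds shown leave open whether a longer chain, a benzyl group, or a chain ending in an amine or a carboxylic acid, in place of the allyl, would also stay within the scatter of compound 1. They also leave open whether the change from allyl to isobutyl would read the same way with a thiocyanate in place of the selenocyanate on the shared core.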